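Biaryl sulfonamide series: indole to dimethylaminophenyl swap

This account rests on a few compounds, and the source may have more. Where it says the series, first, only, none or still open, it means among the compounds named here.

Compound 1 `O=S(=O)(Nc1cccc(CO)c1)c1ccc(-c2ccc3cc[nH]c3c2)cc1` is the anchor of the set. In a functional assay on J774 cells (Mus musculus) for cytotoxicity, read by resazurin assay, with a stated time of 72 h (on this read-out lower numbers stand for stronger inhibition and higher numbers for weaker inhibition), compound 1 gives 2500 nM, the only numerical result among the three values shown. Compound 2 `O=S(=O)(Nc1ccc(-c2ccc(Cl)cc2Cl)cc1)c1cccc(CO)c1` is a sulfonamide of the opposite orientation with a dichlorophenyl terminus; in this assay compound 2 reaches only the limit of > 10000 nM. Compound 3 `O=C(Nc1cccc(CO)c1)c1ccc(-c2ccc(F)cc2F)cc1` is an amide with a difluorophenyl terminus; in this assay compound 3 likewise reaches only the limit of > 15000 nM. Within the data shown here, the two limits (the limit of > 10000 nM in this assay, at which 1 of the 3 values shown sits, and (the limit of > 15000 nM in this assay, at which 1 of the 3 values shown sits)) mean that compound 1 is the sole member with a measurable read-out, and no pair of measured compounds differs in a single place, so no measured step exists.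

Compound 4 `CN(C)c1ccc(-c2ccc(S(=O)(=O)Nc3cccc(CO)c3)cc2)cc1` differs from compound 1 by the change (4-(dimethylamino)phenyl in place of 1H-indol-6-yl on an aromatic carbon). The expectation for this step rests on the structural change alone, with no measured comparison to draw on. A small step toward weaker inhibition is expected, a 1.6-fold higher number from compound 1 to compound 4 (0.20 log units; within the scatter), not clearly beyond the usual scatter of this assay. Compound 4 is therefore estimated at 4000 nM in this assay, within a range from 1500 nM to 12000 nM.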

Compound 4, half-maximal inhibitory concentration: > 5000 nM
Compound 4: only a limit was reported; the forecaster's own chance of this, stated with the estimate: 25%; at least 1.2-fold (0.09 log units) between middle value and limit.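

In this assay compound 4 gives > 5000 nM, which is a limit of the assay and not a number. Among these compounds, the swap of 1H-indol-6-yl for 4-(dimethylamino)phenyl, on an aromatic carbon para to a large group, gives the only single-place comparison, and it reads as an at least 2.0-fold higher number from compound 1 to compound 4 (0.30 log units; that floor lies within the scatter). This step sets only a floor, so it does not show a change clearly beyond the usual scatter, and the true size of the step stays unknown because the result for compound 4 is a limit: the limit of > 5000 nM in this assay, at which 1 of the 4 values shown sits.

Compound 1 remains the only compound with a numerical value, so the compounds shown cannot separate the loss of the five-membered aromatic ring from the exchange of the hydrogen-bond donor for a hydrogen-bond acceptor. Also open, from the compounds shown here alone, is whether a plain phenyl, a 4-aminophenyl or a 4-carboxyphenyl group at this place would give a numerical value, and so show how far the read-out depends on the group on this carbon.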